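The source may report more compounds than this note shows. Statements on the series, on what has been measured and on what is new or still open speak of the compounds shown alone.

In a functional assay on K562 cells (Homo sapiens) for cytotoxicity, read by MTT assay (on this read-out lower numbers stand for stronger inhibition and higher numbers for weaker inhibition), compound 1 (`CCCCC(=O)Oc1cc(/C=C/C(=O)c2ccc(OC)c3c2OC(C)(C)C=C3)ccc1OC`) gives 240 nM and compound 2 (`COc1ccc(/C=C/C(=O)c2ccc(OC)c3c2OC(C)(C)C=C3)cc1OC(=O)CCl`) gives 400 nM. Within the data shown here, these are the only two numbers so far and they lie within the scatter of each other, so compound 2 does not stand apart from compound 1. Compound 3 (`COc1ccc(/C=C/C(=O)c2ccc(OC)c3c2OC(C)(C)C=C3)cc1OC(=O)c1ccco1`) has not yet been measured in this assay. It differs from compound 2 in one group: furan-2-yl in place of chloromethyl on a carbonyl carbon, (furan-2-yl in place of chloromethyl on a carbonyl carbon). Among the measured compounds shown here, only one measured step bears on this, and it too falls on a group bound to a carbonyl carbon: a 1.7-fold higher number from compound 1 to compound 2 (0.22 log units; within the scatter), with chloro in place of propyl on a saturated chain carbon. For the measured compounds named here, that step stayed inside the scatter, but it offers only limited guidance, as no measured compound carries a ring on this carbonyl carbon. No change beyond the scatter is therefore expected, in either direction. The expected step is a 1.3-fold lower number from compound 2 to compound 3 (0.10 log units; within the scatter). For compound 3 the estimated value is 320 nM, with an expected range from 110 nM to 950 nM.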

Compound 3, half-maximal inhibitory concentration: 450 nM
Compound 3: middle estimate off by 1.4-fold (0.15 log units), on the low side; the range from low to high includes it.
By their numbers in this assay, from the lowest: compounds 1, 2 and 3 (each within the scatter of the next).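

In this assay compound 3 is the only compound shown with a ring on this carbonyl carbon, so it gives the first reading of an aromatic group at this place. Furan-2-yl in place of chloromethyl gives a 1.1-fold higher number from compound 2 to compound 3 (0.05 log units; within the scatter) and furan-2-yl in place of butyl gives a 1.9-fold higher number from compound 1 to compound 3 (0.27 log units; within the scatter) so neither step separates the ring from the open-chain groups, and the hydrogen-bond acceptor that enters with the furan-2-yl ring brings no change beyond the scatter in this small set. No evidence is available to explain these numbers.

All three groups shown on this carbonyl carbon therefore give numbers within the scatter of their neighbours, which leaves open whether any group here can move the number beyond it, for example a phenyl ring, a dimethylaminomethyl group or a chain ending in a carboxylic acid. As far as these compounds go, it also remains open whether the same holds with an amide nitrogen in place of the oxygen next to a carbonyl group, or whether a longer chain than butyl would behave as these groups do.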